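This account rests on a few compounds, and the source may have more. Where it says the series, first, only, none or still open, it means among the compounds named here.

Measured in an ADME assay on Vero cells (Chlorocebus sabaeus) for antiproliferative activity, read by MTT assay, with a stated time of 72 h; a higher number here means a weaker inhibitor, a lower number a stronger inhibitor:
- Compound 1 `CN(c1ccccc1Cl)S(=O)(=O)C1CC2OC1C(c1ccc(NC(=O)CCCCCCC(=O)O)cc1)=C2c1ccc(O)cc1`: > 100000 nM (a limit)
- Compound 2 `CCN(c1cccc(C)c1)S(=O)(=O)C1CC2OC1C(c1ccc(NC(=O)CCCCCCC(=O)O)cc1)=C2c1ccc(O)cc1`: > 100000 nM (a limit)

Compound 2 has no exact number here, only the limit > 100000 nM. Compound 3 `CCN(c1ccc(Cl)cc1)S(=O)(=O)C1CC2OC1C(c1ccc(NC(=O)CCCCCCC(=O)O)cc1)=C2c1ccc(O)cc1` differs from it as follows: 4-chlorophenyl in place of 3-methylphenyl on a sulfonamide nitrogen. In words, it has 4-chlorophenyl in place of 3-methylphenyl on a sulfonamide nitrogen.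

For the measured compounds named here, only one measured step bears on this change, and it also alters the substitution on that nitrogen: a step that the two limits leave unreadable from compound 1 to compound 2. It therefore gives no size to carry over, and the only firm observation is the limit of > 100000 nM in this assay, at which 2 of the 2 values shown sit. With only that to go on, no step beyond the scatter is expected in this assay, and another limit is the likeliest report. The expected step is a step that the limit leaves unreadable from compound 2 to compound 3. Compound 3 is estimated at 120000 nM, with an expected range from 60000 nM to 300000 nM.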

Compound 3, half-maximal inhibitory concentration: > 100000 nM
Compound 3: no number, only a limit (the forecaster's own chance of this, stated with the estimate: 85%); the middle value is on the limit's open side.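

In this assay, compound 3 gives > 100000 nM, which is a limit and not a number. For the compounds shown here, compound 1 and compound 2 also give only limits, so no step to compound 3 can be read. Whether the groups on the sulfonamide nitrogen make any difference stays open: the limit of > 100000 nM in this assay, at which 3 of the 3 values shown sit.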